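A few compounds are considered here, and "the series" means these few. Any claim that something is new, unique, unknown or untested is made for them only; others in the source may bear on it.

Compound 1, with the structure `Cc1nc(C(NC(=O)C(=O)Nc2ccc(Cl)cc2)C2CCNCC2)sc1CO`, was run in an ADME assay on TZM-b1 cells (Homo sapiens) for cytotoxicity, read by XTT assay, with a stated time of 3 days; on this read-out lower numbers stand for higher toxicity in this test and higher numbers for lower toxicity in this test. In this assay compound 1 gives 81000 nM. Compound 2, with the structure `Cc1nc(C(NC(=O)C(=O)Nc2ccc(Cl)cc2)C2CCCCN2)sc1CO`, carries piperidin-2-yl in place of piperidin-4-yl on a saturated chain carbon bound to an amide-type nitrogen and an aromatic carbon. In this assay compound 2 reaches only a limit of the assay, > 22000 nM, and not a number. Because of the limit of > 22000 nM in this assay, at which 1 of the 2 values shown sits, the step that the limit leaves unreadable from compound 1 to compound 2 cannot be read in size. Compound 3, with the structure `Cc1nc(C(NC(=O)C(=O)Nc2ccc(F)c(Cl)c2)C2CCCCN2)sc1CO`, differs from compound 2 by 3-chloro-4-fluorophenyl in place of 4-chlorophenyl on an amide-type nitrogen. Among the compounds with values here, no measured step touches this part of the molecule, so nothing measured tells how large the change in this assay might be, and a step no larger than the usual scatter is expected from compound 2 to compound 3, a step that the limit leaves unreadable from compound 2 to compound 3. Compound 3 is therefore expected to give about 50000 nM in this assay, within a range from 20000 nM to 150000 nM.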

Compound 3, half-maximal cytotoxic concentration: > 77800 nM
Compound 3 was reported as a limit; the forecaster's own chance of this, stated with the estimate: 50%; at least 1.5-fold (0.19 log units) between middle value and limit.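

Compound 2 and compound 3 both stand only as limits of the assay in this assay, not as numbers, and the size of the step between them cannot be read. The compounds shown leave open whether 3-chloro-4-fluorophenyl in place of 4-chlorophenyl changes the half-maximal cytotoxic concentration at all, and by how much.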